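Styryl sulfone series: from compound 2 to compound 3

A few compounds are considered here, and "the series" means these few. Any claim that something is new, unique, unknown or untested is made for them only; others in the source may bear on it.

Measured so far in a functional assay on DU-145 cells (Homo sapiens) for inhibition, read by trypan blue exclusion, with a stated time of 96 h; a higher number here means a weaker inhibitor of growth, a lower number a stronger inhibitor of growth
- compound 1 `O=C(/C(=C\c1ccc(Cl)cc1)S(=O)(=O)c1ccc(Br)cc1)c1ccc(Br)cc1` at 50000 nM
- compound 2 `O=C(/C(=C\c1ccc(F)c([N+](=O)[O-])c1)S(=O)(=O)c1ccc(Br)cc1)c1ccc(Br)cc1` at 25000 nM

Compound 2 stands within the scatter of compound 1, so neither stands apart on these numbers. Going by the values given here, the only measured step is a 2.0-fold lower number from compound 1 to compound 2 (0.30 log units; within the scatter) and it exchanged the group at the same place as the change now in view.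

Compound 3 `COc1ccc(/C=C(\C(=O)c2ccc(Br)cc2)S(=O)(=O)c2ccc(Br)cc2)cc1` is not yet measured. Its difference from compound 2 is 4-methoxyphenyl in place of 4-fluoro-3-nitrophenyl on a double-bonded chain carbon bound to a double-bonded chain carbon with 4-methoxyphenyl in place of 4-fluoro-3-nitrophenyl on a double-bonded chain carbon bound to a double-bonded chain carbon. Among the compounds with values here, no measured compound carries 4-methoxyphenyl, and one step is thin evidence. No change beyond the scatter is therefore expected in this assay and the estimated change is a 1.2-fold higher number from compound 2 to compound 3 (0.08 log units; within the scatter) on this basis.

The estimate for compound 3 is 30000 nM with an expected range of 8000 nM to 100000 nM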

Compound 3, concentration for 50% growth inhibition: 25000 nM
Beside the measured number, compound 3's estimate is 1.2-fold (0.08 log units) above it; low and high end bracket the measured number.
By their numbers in this assay, from the lowest: compounds 2, 3 and 1 (each within the scatter of the next).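

In this assay, 4-methoxyphenyl in place of 4-fluoro-3-nitrophenyl on a double-bonded chain carbon bound to a double-bonded chain carbon gives no change at the digits printed from compound 2 to compound 3 (within the scatter), and methoxy in place of chloro on an aromatic carbon gives a 2.0-fold lower number from compound 1 to compound 3 (0.30 log units; within the scatter). All three groups at this place now lie within the scatter of one another, even though the exchange from compound 2 to compound 3 removes the nitro and fluoro substituents and changes the heavy-atom and acceptor counts. No evidence on the cause of this flat result is available.

As far as these compounds go, whether an amine, a carboxylic acid or a longer chain on the aromatic ring at this place would move the number beyond the scatter remains open. From the compounds shown here alone, the rest of the shared core is the same in all three compounds, so the effect of changes there is also open.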